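Methoxy Removal on a Fluorine-Free Sulfonamide Core

A few compounds are considered here, and "the series" means these few. Any claim that something is new, unique, unknown or untested is made for them only; others in the source may bear on it.

Three compounds have been measured in a functional assay on HeLa cells (Homo sapiens) for antiproliferative activity, read by MTT assay, with a stated time of 48 h; on this read-out higher numbers stand for weaker inhibition and lower numbers for stronger inhibition:
Compound 1, `NS(=O)(=O)c1ccc(Nc2ncc(F)c(Nc3nc4ccccc4s3)n2)cc1`, gives 4520 nM.
Compound 2, `COc1ccc2nc(Nc3nc(Nc4ccc(S(N)(=O)=O)cc4)ncc3F)sc2c1`, gives 13000 nM.
Compound 3, `COc1ccc2nc(Nc3ccnc(Nc4ccc(S(N)(=O)=O)cc4)n3)sc2c1`, gives 1730 nM.

Compound 3 holds the lowest number of the three. Compound 2 and compound 3 share one core and differ by hydrogen in place of fluoro on an aromatic carbon, a step of a 7.5-fold lower number from compound 2 to compound 3 (0.88 log units; beyond the scatter). Compound 2 and compound 1 differ by hydrogen in place of methoxy on an aromatic carbon, a step of a 2.9-fold lower number from compound 2 to compound 1 (0.46 log units; beyond the scatter).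

Compound 4, `NS(=O)(=O)c1ccc(Nc2nccc(Nc3nc4ccccc4s3)n2)cc1`, has not yet been measured in this assay. It differs from compound 3 by hydrogen in place of methoxy on an aromatic carbon. This is the same change that separates compound 2 from compound 1, here carried out on the core of compound 3, and it occurs twice among these four compounds.

Compound 4 is expected to give a step of a 2.5-fold lower number from compound 3 to compound 4 (0.39 log units; beyond the scatter) in this assay, resting on the change from compound 2 to compound 1, which gave a 2.9-fold lower number from compound 2 to compound 1 (0.46 log units; beyond the scatter). Whether the step repeats on the fluorine-free core cannot be known from two compounds alone. The estimate for compound 4 is 700 nM, between 250 nM and 2000 nM.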

Compound 4, half-maximal inhibitory concentration: 2060 nM
For compound 4 the middle estimate is 2.9-fold (0.47 log units) below the measured one; measured number above the stated range.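

Carried onto the fluorine-free core in this assay, hydrogen in place of methoxy gives a 1.2-fold higher number from compound 3 to compound 4 (0.08 log units; within the scatter), and set beside the same change on the fluorine-bearing core, the step does not transfer: the same change on two cores in this assay, a 2.9-fold lower number (0.46 log units; beyond the scatter) from compound 2 to compound 1 and a 1.2-fold higher number (0.08 log units; within the scatter) from compound 3 to compound 4, 3.4-fold (0.53 log units) apart, beyond the scatter of two such steps

Hydrogen in place of fluoro lowers the number on both cores, with a 2.2-fold lower number from compound 1 to compound 4 (0.34 log units; beyond the scatter) where methoxy is absent, but the size of that step does not transfer either: the same change on two cores in this assay, a 7.5-fold lower number (0.88 log units; beyond the scatter) from compound 2 to compound 3 and a 2.2-fold lower number (0.34 log units; beyond the scatter) from compound 1 to compound 4, 3.4-fold (0.53 log units) apart, beyond the scatter of two such steps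

Among these four compounds, then, the effect of each change depends on the group present at the other place, but the data do not show why the steps differ or whether this holds for other compounds in the series.

The compounds shown leave open how an amine or a longer alkoxy chain in place of methoxy would behave on these two cores. They also leave open whether chloro in place of fluoro would give steps that differ between cores in the same way.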